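From a Nitrothiophene to a Bromo-Ethoxy Aryl Group

The compounds below may be only part of what the source reports. "The series", "measured", "known", "first", "only" and "open" are said of these compounds alone.

Of the compounds shown here, two sharing one core have been measured in a functional assay on MIA PaCa-2 cells (Homo sapiens) for inhibition, read by MTT assay, with a stated time of 48 h, tested at 10 uM; on this read-out higher numbers stand for more inhibition of growth at the one concentration tested and lower numbers for less inhibition of growth. Compound 1 (`Cc1oc2c([C@H]3CCN(C)C[C@H]3O)c(O)cc(O)c2c(=O)c1C(O)c1ccc([N+](=O)[O-])cc1`) gives 2%, and compound 2 (`Cc1oc2c([C@H]3CCN(C)C[C@H]3O)c(O)cc(O)c2c(=O)c1C(O)c1csc([N+](=O)[O-])c1`) gives 41%, the higher of the two numbers. Compound 3 (`CCOc1ccc(Br)c(C(O)c2c(C)oc3c([C@H]4CCN(C)C[C@H]4O)c(O)cc(O)c3c2=O)c1`) keeps that core but carries 2-bromo-5-ethoxyphenyl in place of 5-nitrothiophen-3-yl on a saturated chain carbon bound to an aromatic carbon and an oxygen on a saturated carbon.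

Going by the values given here, only one measured step bears on this change. At the same place, the data show a number 39 percentage points higher from compound 1 to compound 2 (beyond the scatter), a large step that marks this site as one where the number can move strongly. Compound 3 returns to a six-membered aromatic ring of carbon only, a ring type also found in compound 1 at 2%, although the groups on that ring differ and neither measured compound carries the bromine or the ethoxy group. A moderate fall in this assay is therefore expected, with the estimated change being a number 19 percentage points lower from compound 2 to compound 3 (beyond the scatter). The estimate for compound 3 is 22%, with an expected range from 5% to 45%.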

Compound 3, percent growth inhibition at one concentration: 4%
For compound 3 the middle estimate is 18 percentage points above the measured one, and the stated range ends above it.
By their numbers in this assay, from the lowest: compounds 1 and 3 (each within the scatter of the next); then compound 2.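

In this assay, 2-bromo-5-ethoxyphenyl in place of 5-nitrothiophen-3-yl on this saturated chain carbon gives a number 37 percentage points lower from compound 2 to compound 3 (beyond the scatter) in a large step, so the site proves able to lose as much as it gained in the earlier comparison. Among the two groups built on a six-membered aromatic ring of carbon only, the change to 2-bromo-5-ethoxyphenyl from 4-nitrophenyl gives a number 2 percentage points higher from compound 1 to compound 3 (within the scatter) and leaves the two compounds unseparated, although the groups on those rings share no substituent. Of the three compounds, compound 2 alone, with its five-membered aromatic ring with one hetero atom, stands clear of the others, and nothing in the data given here accounts for these steps.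

The compounds shown leave open whether the higher reading of compound 2 goes with the sulfur-containing ring itself or with the nitro group on it, a question that a plain thiophen-3-yl group or a 5-nitrofuran-3-yl group would address. They also leave open what the bromine and the ethoxy group each contribute, as a phenyl ring carrying only one of them would show.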